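The compounds below may be only part of what the source reports. "The series", "measured", "known", "first", "only" and "open" are said of these compounds alone.

Measured compounds:
compound 1 `C=CCOc1ccc(C(=O)Nc2cccc(Br)n2)cc1`: 65500 nM
compound 2 `CCCOc1ccc(C(=O)Nc2cnccn2)cc1`: 22500 nM
compound 3 `CCCCCNc1cccc(NC(=O)c2ccc(OCCC)cc2)n1`: > 100000 nM

In an in vitro assay on HEK-tsA201 cells for antagonist activity at Neuronal acetylcholine receptor; alpha3/beta4 (Homo sapiens), read by fluorescence and calcium flux (on this read-out higher numbers stand for weaker inhibition and lower numbers for stronger inhibition), compound 1 gives 65500 nM and compound 2 gives 22500 nM. Compound 3 stands apart from these two, since for compound 3 the read-out is only a limit of the assay and not a number: it sits at the limit of > 100000 nM in this assay, at which 1 of the 3 values shown sits, so no value for compound 3 can be placed against the others beyond saying that it was not resolved. For the measured compounds named here, no pair among the three measured compounds differs in a single place, so no measured step is available to guide a prediction.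

Compound 4 `CCCOc1ccc(C(=O)Nc2cccc(NCc3ccccc3)n2)cc1` differs from compound 3 by phenyl in place of butyl on a saturated chain carbon bound to a nitrogen on an aromatic ring. With no measured step of this kind in hand, the expectation for this change rests only on compound 3 sitting at its limit: a step of modest size is expected, not clearly beyond the usual scatter, and if anything toward stronger inhibition, with a real chance that compound 4 again returns only a limit. Compound 4 is therefore estimated at 80000 nM, within 20000 nM to 300000 nM, which would mean an expected step of an at least 1.2-fold lower number from compound 3 to compound 4 (0.09 log units; that floor lies within the scatter).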

Compound 4, half-maximal inhibitory concentration: > 100000 nM
Compound 4: a limit, no number; the forecaster's own chance of this, stated with the estimate: 55%; middle value at least 1.2-fold (0.09 log units) from the limit.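

Compound 4, like compound 3, returns only a limit of the assay and not a number in this assay and so no step can be read between the two: the limit of > 100000 nM in this assay, at which 2 of the 4 values shown sit.

The compounds shown leave open whether phenyl in place of butyl on a saturated chain carbon bound to a nitrogen on an aromatic ring changes inhibition at all.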